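Swapping benzyl for (pyridin-2-yl)methyl: compound 3 to compound 4

A few compounds are considered here, and "the series" means these few. Any claim that something is new, unique, unknown or untested is made for them only; others in the source may bear on it.

Compound 1 `CS(=O)(=O)Nc1ccc2c(c1)S(=O)(=O)N=C(c1c(O)c(-c3cccs3)nn(CCC3CC3)c1=O)N2` gives > 33000 nM (a limit)
Compound 2 `COCCn1nc(-c2cccs2)c(O)c(C2=NS(=O)(=O)c3cc(NS(C)(=O)=O)ccc3N2)c1=O` gives > 1000 nM (a limit)
Compound 3 `CS(=O)(=O)Nc1ccc2c(c1)S(=O)(=O)N=C(c1c(O)c(-c3cccs3)nn(Cc3ccccc3)c1=O)N2` gives > 1000 nM (a limit)

In an ADME assay on Huh-7 cells (Homo sapiens) for cytotoxicity, with a stated time of 72 h (on this read-out lower numbers stand for higher toxicity in this test and higher numbers for lower toxicity in this test), compound 3 gives > 1000 nM as a limit and not as a number. Compound 3 stands at the limit of > 1000 nM in this assay, at which 2 of the 3 values shown sit, and compound 2 is the other compound there. Compound 1 stands at the limit of > 33000 nM in this assay, at which 1 of the 3 values shown sits, and so none of the three has a number.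

Compound 4 `CS(=O)(=O)Nc1ccc2c(c1)S(=O)(=O)N=C(c1c(O)c(-c3cccs3)nn(Cc3ccccn3)c1=O)N2` has not yet been measured. It departs from compound 3 in one place (pyridin-2-yl in place of phenyl on a saturated chain carbon bound to an aromatic nitrogen) and this reads as pyridin-2-yl in place of phenyl on a saturated chain carbon bound to an aromatic nitrogen.

The measured changes at that carbon are a step that the two limits leave unreadable from compound 1 to compound 3 for phenyl in place of cyclopropylmethyl and a step that the two limits leave unreadable from compound 2 to compound 3 for phenyl in place of methoxymethyl. Neither offers a size or a direction to carry over. No step beyond the usual scatter is therefore expected, in either direction, and compound 4 is expected to stay among these weakly toxic readings. The estimated step, measured against a limit and not a number, reads a step that the limit leaves unreadable from compound 3 to compound 4 and carries no more weight than that. Compound 4 is estimated at 20000 nM with an expected range from 2000 nM to 50000 nM in this assay. Compound 4 may again give only a limit.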

Compound 4, half-maximal cytotoxic concentration: > 1000 nM
Compound 4: only a limit was reported; the forecaster's own chance of this, stated with the estimate: 85%; the middle value is on the limit's open side.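

In this assay compound 4 gives > 1000 nM, a limit and not a number. For the compounds shown here, no step can therefore be read from compound 1, compound 2 or compound 3 to compound 4. The compounds shown leave open where any of them would reach a half-maximal cytotoxic concentration, and whether pyridin-2-yl in place of phenyl changes it at all.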